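The compounds below may be only part of what the source reports. "The series", "measured", "known", "first", "only" and "open" are said of these compounds alone.

Compound 1 `O=C(Nc1ccc(Cl)c(-c2nnc3c(Cl)cccn23)c1)c1ccc(F)cc1Cl` is the reference amide of this set. In a functional assay on HeLa cells (Homo sapiens) for antiproliferative activity, read by MTT assay, with a stated time of 72 h (a higher number here means a weaker inhibitor, a lower number a stronger inhibitor), compound 1 gives > 100000 nM, which is a limit of the assay and not a number. Compound 2 `O=C(Nc1ccc(Cl)c(-c2nnc3c(Cl)cccn23)c1)c1cccnc1` carries a pyridin-3-yl on the carbonyl carbon instead; in this assay compound 2 gives > 100000 nM, again a limit. Compound 3 `O=C(Nc1ccc(Cl)c(-c2nnc3c(Cl)cccn23)c1)c1ccc(Cl)cc1Cl` carries a 2,4-dichlorophenyl there; in this assay compound 3 gives > 100000 nM, also a limit. The three steps among them, a step that the two limits leave unreadable from compound 1 to compound 2, a step that the two limits leave unreadable from compound 1 to compound 3 and a step that the two limits leave unreadable from compound 2 to compound 3, cannot be sized because of the limit of > 100000 nM in this assay, at which 3 of the 3 values shown sit. Among the measured compounds shown here, compound 3 thus stands at the limit, with no readable number anywhere so far. Compound 4 `CS(=O)(=O)c1cccc(C(=O)Nc2ccc(Cl)c(-c3nnc4c(Cl)cccn34)c2)c1` differs from compound 3 by 3-(methylsulfonyl)phenyl in place of 2,4-dichlorophenyl on a carbonyl carbon. For the measured compounds named here, none of the measured steps reads on this change, since each of them runs from one limit to another. The expected step from compound 3 is a step that the limit leaves unreadable from compound 3 to compound 4 in this assay, meaning no readable movement. Compound 4 is therefore estimated at 150000 nM, within 30000 nM to 600000 nM, and will most probably again be reported only as a limit.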

Compound 4, half-maximal inhibitory concentration: 86400 nM
The estimate for compound 4 lay 1.7-fold (0.24 log units) above the measured number; low and high end bracket the measured number.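

Among the compounds shown here, on the carbonyl carbon, 3-(methylsulfonyl)phenyl gives the first readable number of the series: in this assay compound 4 gives 86400 nM. The steps to it are only floors, an at least 1.1-fold lower number from compound 3 to compound 4 (0.06 log units; that floor lies within the scatter), an at least 1.1-fold lower number from compound 2 to compound 4 (0.06 log units; that floor lies within the scatter) and an at least 1.1-fold lower number from compound 1 to compound 4 (0.06 log units; that floor lies within the scatter), so this change is not shown to move the number beyond the usual scatter. Their true sizes cannot be read because the other three compounds give no number: the limit of > 100000 nM in this assay, at which 3 of the 4 values shown sit.

Still open, as far as these compounds go, is whether the readable number belongs to the methylsulfonyl group specifically, which a phenyl ring carrying a sulfonamide, a carboxylic acid or an amine in its place would test. Also open, from the compounds shown here alone, is whether a longer chain on the sulfonyl sulfur, in place of the methyl, would keep a number within the range of the assay.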